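This account rests on a few compounds, and the source may have more. Where it says the series, first, only, none or still open, it means among the compounds named here.

In an ADME assay on MCF-10A cells (Homo sapiens) for inhibition, with a stated time of 48 h (on this read-out lower numbers stand for stronger inhibition and higher numbers for weaker inhibition), compound 3 `Cc1cccc(-c2noc([C@@H]3CCCN3C(=O)Nc3ccc(Cl)cc3)n2)c1` gives > 50000 nM, which is a limit. Compound 1 `N#Cc1ccc(NC(=O)N2CCC[C@H]2c2nc(-c3ccccc3)no2)cc1` gives > 50000 nM, also a limit. Compound 2 `O=C(Nc1ccc([N+](=O)[O-])cc1)N1CCC[C@H]1c1nc(-c2ccccc2)no1` gives > 50000 nM, again a limit. Across the series this is the limit of > 50000 nM in this assay, at which 3 of the 3 values shown sit. Compound 4 `Cc1ccc(-c2noc([C@@H]3CCCN3C(=O)Nc3ccc(Cl)cc3)n2)cc1` differs from compound 3 by 4-methylphenyl in place of 3-methylphenyl on an aromatic carbon: 4-methylphenyl in place of 3-methylphenyl, on an aromatic carbon between two ring nitrogen atoms. For the measured compounds named here, the only measured step, a step that the two limits leave unreadable from compound 1 to compound 2, involves other groups and has no readable size, so it offers no size to carry over. No step beyond the scatter is expected, in either direction. The expected change is a number no higher from compound 3 to compound 4 (the limit leaves the size open). Compound 4 is estimated at 50000 nM, with an expected range from 25000 nM to 100000 nM, and is most likely to be reported as a limit again.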

Compound 4, half-maximal inhibitory concentration: > 50000 nM
Compound 4: no number, only a limit (the forecaster's own chance of this, stated with the estimate: 85%); the middle value lies on the limit itself.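

No step can be read from compound 3 to compound 4, as both values in this assay are limits. The compounds shown leave open the size of any methylphenyl position effect and any ranking within the series: the limit of > 50000 nM in this assay, at which 4 of the 4 values shown sit.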